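The source may hold more compounds than are shown below. What is called first, only, known or untested is meant among the compounds shown, and "the series" means these compounds.

Measured in a functional assay on MCF7 cells (Homo sapiens) for antiproliferative activity, read by luminescence and CellTiter-Glo, with a stated time of 48 h; a higher number here means a weaker inhibitor, a lower number a stronger inhibitor:
- compound 1 `O=C1CCC[C@@H]([C@H]2C[C@@H]2c2ccccc2)O1`: > 100000 nM (limit)
- compound 2 `O=C1C=CC[C@H]([C@@H]2C[C@H]2c2ccccc2)O1`: > 100000 nM (limit)

Among the measured compounds shown here, the series so far offers no number, only (the limit of > 100000 nM in this assay, at which 2 of the 2 values shown sit). Compound 2 gives > 100000 nM in this assay, which is a limit of the assay and not a number. For the measured compounds named here, it therefore marks no position relative to compound 1, and no measured step is available to size an effect of any structural change.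

Next comes compound 3 `O=C1C=CC[C@H]([C@H]2C[C@@H]2c2ccccc2)O1`, a stereoisomer of compound 2: the two compounds have the same atoms and bonds and differ only in configuration as drawn: 2 of 3 stereo elements differ; a stereocentre at a saturated ring carbon is drawn R in compound 2 and S in compound 3; a stereocentre at a saturated ring carbon is drawn R in compound 2 and S in compound 3. No group leaves or enters, and the change lies in configuration alone.

Compound 2 offers only its limit > 100000 nM as a base for an expectation. The expected a number no higher from compound 2 to compound 3 (the limit leaves the size open) is none beyond the scatter, in either direction, and a further report of a limit is considered likely. These data cannot rule out a measurable value, so the estimated range extends downward. For compound 3 the estimated value is 100000 nM, with an expected range from 30000 nM to 200000 nM.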

Compound 3, half-maximal inhibitory concentration: 48200 nM
The estimate for compound 3 lay 2.1-fold (0.32 log units) above the measured number; the range from low to high includes it.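

In this assay, the series now has its first measurable value, and it comes with no group leaving or entering: the step is an at least 2.0-fold lower number from compound 2 to compound 3 (0.31 log units; beyond the scatter). The value for compound 2 is a limit of the assay and not a number, > 100000 nM, and the size of the step therefore has only a lower bound. The step can be tied to the two stereocentres at saturated ring carbons, the only place where the structures part, and the ground for this reading is: the fact that compounds 2 and 3 differ only in the configuration as drawn.

Both stereocentres change together in this one step, which leaves open the share of each, and no pair shown isolates the carbon-carbon double bond of the core, so its contribution in this assay also cannot be read. Also open, on these data alone, is whether the configuration of compound 3 would hold its value, or move it further from the limit, with a new group on the shared core, such as an amine, a hydroxyl or a carboxylic acid.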